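Hydroxy added to a chlorophenyl arm of a bis-benzylidene ketone

A few compounds are considered here, and "the series" means these few. Any claim that something is new, unique, unknown or untested is made for them only; others in the source may bear on it.

Compound 1 `COc1ccc(/C=C2\CCC/C(=C\c3cccc(OC)c3OC)C2=O)cc1`: 43500 nM
Compound 2 `COc1cccc(/C=C2\CCC/C(=C\c3ccc(O)c(Cl)c3)C2=O)c1OC`: 39500 nM
Compound 3 `COc1ccc(/C=C2\CCC/C(=C\c3cccc(Cl)c3)C2=O)cc1OC`: 11900 nM

Three compounds sharing one core were measured in an ADME assay on NHDF cells (Homo sapiens) for cytotoxicity, read by MTT assay, with a stated time of 72 h; a lower number here means a stronger inhibitor, a higher number a weaker inhibitor. Compound 3 holds the lowest number of the three; the nearest is compound 2, which gives 39500 nM, and the furthest is compound 1, which gives 43500 nM. Both of those gaps lie beyond the scatter, so compound 3 is the strongest inhibitor in this assay among the measured set.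

Compound 4 `COc1ccc(/C=C2\CCC/C(=C\c3ccc(O)c(Cl)c3)C2=O)cc1OC` has not yet been measured. It differs from compound 3 in one place: hydroxy in place of hydrogen on an aromatic carbon The hydroxy enters on an aromatic carbon of a six-membered aromatic ring of carbon only, ortho to a chloro group and para to a large group, so that 3-chlorophenyl becomes 3-chloro-4-hydroxyphenyl.

Among the measured compounds shown here, only one measured step bears on it indirectly. The step of a 1.1-fold lower number from compound 1 to compound 2 (0.04 log units; within the scatter) replaces 4-methoxyphenyl with 3-chloro-4-hydroxyphenyl and stays within the scatter. For the measured compounds named here, no measured pair shows hydroxy alone entering beside an existing chloro group. Given that the related step from compound 1 to compound 2 was within the scatter, compound 4 is expected to show a step of about a 1.3-fold higher number from compound 3 to compound 4 (0.10 log units; within the scatter) in this assay, with no clear direction beyond the scatter. Compound 4 is therefore estimated at 15000 nM, in a range from 6000 nM to 40000 nM.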

Compound 4, half-maximal inhibitory concentration: 21900 nM
Compound 4: the middle estimate sits 1.5-fold (0.16 log units) below what was measured; low and high end bracket the measured number.
By their numbers in this assay, from the lowest: compounds 3, 4, 2 and 1 (each within the scatter of the next, the first and the last beyond it).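

In this assay, among the compounds shown here, the change from 3-chlorophenyl to 3-chloro-4-hydroxyphenyl gives a 1.8-fold higher number from compound 3 to compound 4 (0.26 log units; within the scatter), and this is the first reading of hydroxy alone entering on this aromatic carbon, ortho to a chloro group and para to a large group; the earlier step, a 1.1-fold lower number from compound 1 to compound 2 (0.04 log units; within the scatter), exchanged a whole aryl group and altered the other substituents with it. With the rest of the molecule held fixed, the added hydroxy therefore does not shift the number beyond the usual scatter of repeated measurements, so neither a gain nor a loss can be assigned to it on this evidence. Nothing measured here accounts for the result at the level of mechanism.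

The compounds shown leave open whether hydroxy would behave the same way on an aryl group carrying no chloro group, or with a different arm on the other side of the shared core. They also leave open whether an amine, a carboxylic acid or a methoxy group on this same aromatic carbon would give a step beyond the scatter in this assay.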